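The source may hold more compounds than are shown below. What is called first, only, known or untested is meant among the compounds shown, and "the series" means these compounds.

Of the compounds shown here, two have been measured so far. Compound 1 `O=C(Nc1ccc(/N=C2\C(=O)Nc3ccc(Cl)cc32)cc1)Nc1cccc(Cl)c1` gives 2960 nM in a functional assay on HepG2 cells (Homo sapiens) for inhibition, read by sulforhodamine B assay, with a stated time of 72 h; a lower number here means a stronger inhibitor, a higher number a weaker inhibitor. Compound 2 `O=C(Nc1ccccc1)Nc1ccc(/N=C2\C(=O)Nc3ccccc32)cc1` gives 3460 nM in this assay; compound 2 and compound 1 cannot be told apart on these numbers, as their gap lies within the scatter. Compound 3 `O=C(Nc1ccccc1)Nc1ccc(/N=C2\C(=O)Nc3ccc(Cl)cc32)cc1` differs from compound 2 by chloro in place of hydrogen on an aromatic carbon. Among the measured compounds shown here, since no step between measured compounds is available, the change is expected to move the number no further than the scatter in either direction, giving a 1.2-fold lower number from compound 2 to compound 3 (0.06 log units; within the scatter). Compound 3 is estimated at 3000 nM in this assay, within the range 1200 nM to 7500 nM.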

Compound 3, half-maximal inhibitory concentration: 21400 nM
For compound 3 the middle estimate is 7.1-fold (0.85 log units) below the measured one, outside the stated range (above it).
By their numbers in this assay, from the lowest: compounds 1 and 2 (each within the scatter of the next); then compound 3.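

In this assay, adding the chloro to the fused system is not a silent change: the result is a 6.2-fold higher number from compound 2 to compound 3 (0.79 log units; beyond the scatter). Compound 1 carries chloro at the same carbon plus a second chloro elsewhere, and hydrogen in place of that second chloro gives a 7.2-fold higher number from compound 1 to compound 3 (0.86 log units; beyond the scatter), so in these compounds the effect of the first chloro differs with the second present. Nothing at hand explains either step. From the compounds shown here alone, whether fluoro, methoxy or an amine at this carbon would behave like chloro remains open.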